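Aryl Swap with No Directly Matching Precedent

The source may report more compounds than this note shows. Statements on the series, on what has been measured and on what is new or still open speak of the compounds shown alone.

Compound 1 `C=CCc1ccc(OCc2cn(-c3cccc(C#N)c3)nn2)c(O)c1` and compound 2 `C=CCc1ccc(OCc2cn(-c3cccc([N+](=O)[O-])c3)nn2)c(O)c1` were tested in a functional assay on MIA PaCa-2 cells (Homo sapiens) for inhibition, read by MTT assay, with a stated time of 72 h, tested at 30 uM; a higher number here means more inhibition of growth at the concentration tested, a lower number less inhibition of growth. Compound 1 gives 26.6%, the lowest of the two numbers, while compound 2 gives 42.9%. Within the data shown here, the only measured step, a number 16.3 percentage points higher from compound 1 to compound 2 (beyond the scatter), exchanges one group for another on the same aromatic ring and does not cover the change to compound 3. Compound 3 `C=CCc1ccc(OCc2cn(-c3ccc(OC)cc3)nn2)c(O)c1` differs from compound 1 by 4-methoxyphenyl in place of 3-cyanophenyl on an aromatic nitrogen. Among the measured compounds shown here, with no step bearing on it, no change beyond the scatter is expected in either direction. Compound 3 is therefore estimated at 30%, between 10% and 50%, an expected step of a number 3.4 percentage points higher from compound 1 to compound 3 (within the scatter).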

Compound 3, percent growth inhibition at one concentration: 62.3%
Compound 3: the middle estimate sits 32.3 percentage points below what was measured; measured number above the stated range.
By their numbers in this assay, from the lowest: compound 1; then compound 2; then compound 3.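

In this assay, 4-methoxyphenyl in place of 3-cyanophenyl on the aromatic nitrogen gives a number 35.7 percentage points higher from compound 1 to compound 3 (beyond the scatter), a larger step than the nitrile-to-nitro exchange. The aryl group on this nitrogen can therefore shift growth inhibition strongly, even though the two groups match in heavy atoms and hydrogen-bond acceptors. No measurement here accounts for the step.

This swap changes both the substituent and its place on the phenyl ring, so the two effects cannot be separated. The 3-methoxyphenyl and 4-cyanophenyl groups would help to tell them apart.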